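Swapping a Piperidine Ring for a Piperazine Ring

The compounds below may be only part of what the source reports. "The series", "measured", "known", "first", "only" and "open" are said of these compounds alone.

Of the compounds shown here, three from one series have been tested in an ADME assay on MT4 cells (Homo sapiens) for cytotoxicity, read by MTT assay, with a stated time of 5 days; a lower number here means that less compound is tolerated, a higher number that more compound is tolerated. Compound 1 `COc1cc(Cc2cnc(/N=C3\C(=O)N(CN4CCN(Cc5ccccc5)CC4)c4ccc(Cl)cc43)nc2N)cc(OC)c1OC` gives 36.1 ug/mL. Compound 2 `CCn1cc(C(=O)O)c(=O)c2cc(F)c(N3CCN(CN4C(=O)/C(=N\c5ncc(Cc6cc(OC)c(OC)c(OC)c6)c(N)n5)c5cc(Cl)ccc54)C(C)C3)c(F)c21` gives 36.9 ug/mL. Compound 3 `COc1cc(Cc2cnc(/N=C3\C(=O)N(CN4CCC(C)CC4)c4ccc(Cl)cc43)nc2N)cc(OC)c1OC` gives 67.4 ug/mL. These three numbers differ from one another only by amounts that fall within the usual scatter of repeated measurements, so on the data shown no compound can be said to be tolerated better or worse than another.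

Compound 4 `COc1cc(Cc2cnc(/N=C3\C(=O)N(CN4CCN(C)CC4)c4ccc(Cl)cc43)nc2N)cc(OC)c1OC` has not yet been measured. It differs from compound 3 in a single place: 4-methylpiperazin-1-yl in place of 4-methylpiperidin-1-yl on a saturated chain carbon bound to an amide-type nitrogen in a ring. The two rings are of the same size and carry the same number of heavy atoms; the difference lies in one ring carbon being replaced by a ring nitrogen.

Within the data shown here, since the three compounds measured so far, with differing groups at this position, all land close together, the step from compound 3 to compound 4 in this assay is expected to be small, and a direction cannot be read from the data. The estimate for compound 4 is therefore 45 ug/mL, within a range of 20 ug/mL to 95 ug/mL, which corresponds to an expected step of a 1.5-fold lower number from compound 3 to compound 4 (0.18 log units; within the scatter).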

Compound 4, half-maximal cytotoxic concentration: 80.7 ug/mL
Compound 4: the middle estimate sits 1.8-fold (0.25 log units) below what was measured; low and high end bracket the measured number.
By their numbers in this assay, from the lowest: compounds 1, 2, 3 and 4 (each within the scatter of the next, the first and the last beyond it).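

In this assay this position now has its first direct comparison: 4-methylpiperazin-1-yl in place of 4-methylpiperidin-1-yl gives a 1.2-fold higher number from compound 3 to compound 4 (0.08 log units; within the scatter) and so, on these numbers, exchanging one ring carbon for a ring nitrogen does not measurably change how much compound the cells tolerate. Among these compounds, a second comparison looks further out on the same ring, where hydrogen in place of phenyl on a saturated chain carbon bound to an amine nitrogen in a ring gives a 2.2-fold higher number from compound 1 to compound 4 (0.35 log units; beyond the scatter) and is the only step here that clears the scatter, although it remains modest. With only this one pair, it cannot be said that the outer part of the group generally matters more than the ring atom, and nothing shown explains either step.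

On these data alone, it remains open whether a morpholin-4-yl ring or an open-chain dimethylamino group at this position would stay in the same range as compound 3 and compound 4. As far as these compounds go, it is also open whether an ethyl or propyl chain on the ring nitrogen would give a number closer to compound 4 or to compound 1.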